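The source may report more compounds than this note shows. Statements on the series, on what has been measured and on what is new or still open speak of the compounds shown alone.

Measured so far in a functional assay on NCI-H661 cells (Homo sapiens) for antiproliferative activity, read by MTT assay, with a stated time of 72 h (on this read-out lower numbers stand for stronger inhibition and higher numbers for weaker inhibition), for these compounds
Compound 1 `Nc1ccccc1NC(=O)CCCCCCc1nc(-c2cccc([N+](=O)[O-])c2)no1` gives 7290 nM
Compound 2 `O=C(CCCCCCc1nc(-c2ccccc2)no1)C(F)(F)F` gives 520 nM

Compound 2 holds the lower of the two numbers, and the gap to compound 1 lies beyond the scatter. Compound 3 `O=C(CCCCCCc1nc(-c2cccc([N+](=O)[O-])c2)no1)C(F)(F)F` differs from compound 2 by one change, (nitro in place of hydrogen on an aromatic carbon), with nitro in place of hydrogen on an aromatic carbon. Among the compounds with values here, compound 1 also carries nitro, but it differs from compound 2 elsewhere too, so no measured step isolates this change. The estimate is a 1.2-fold higher number from compound 2 to compound 3 (0.06 log units; within the scatter) in this assay, a small rise expected to stay within the scatter. For compound 3 the expected value is 600 nM with an estimated range from 200 nM to 1800 nM in all.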

Compound 3, half-maximal inhibitory concentration: 6430 nM
Estimate against measurement, compound 3: 11-fold (1.03 log units) below; the whole stated range lies below it.
By their numbers in this assay, from the lowest: compound 2; then compounds 3 and 1 (each within the scatter of the next).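

In this assay, this position on the aromatic ring proves sensitive: nitro in place of hydrogen, meta to a large group, gives a large step (a 12-fold higher number from compound 2 to compound 3 (1.09 log units; beyond the scatter)). With nitro present, trifluoromethyl in place of (2-aminophenyl)amino on a carbonyl carbon leaves the two values within the scatter (a 1.1-fold lower number from compound 1 to compound 3 (0.05 log units; within the scatter)). No measurement shown here accounts for the nitro step. As far as these compounds go, it remains open whether an amine or a methoxy group at this position would give a similar step, and whether the carbonyl swap would also stay within the scatter without nitro.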